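Taking the Nitro Group Off Compound 3

This account rests on a few compounds, and the source may have more. Where it says the series, first, only, none or still open, it means among the compounds named here.

In a functional assay on Jurkat cells (Homo sapiens) for antiproliferative activity, read by MTT assay, with a stated time of 72 h (on this read-out lower numbers stand for stronger inhibition and higher numbers for weaker inhibition), three compounds built on one shared core have been measured so far. Compound 1 (`COc1cc(-c2ncnn2-c2ccc(Cl)cc2Cl)cc(OC)c1OC`) gives > 10000 nM, which is a limit of the assay. Compound 2 (`COc1cc(-c2ncnn2-c2ccc(F)cc2)cc(OC)c1OC`) gives > 10000 nM, again a limit. Compound 3 (`COc1cc(-c2ncnn2-c2ccc([N+](=O)[O-])cc2)cc(OC)c1OC`) gives > 10000 nM, also a limit and not a number. It therefore has no readable place in the series, and the whole picture so far is the limit of > 10000 nM in this assay, at which 3 of the 3 values shown sit.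

The next compound, compound 4 (`COc1cc(-c2ncnn2-c2ccccc2)cc(OC)c1OC`), carries hydrogen in place of nitro on an aromatic carbon, para to a large group: hydrogen in place of nitro on an aromatic carbon. Among the compounds with values here, two measured steps bear on this change: a step that the two limits leave unreadable from compound 1 to compound 2 and a step that the two limits leave unreadable from compound 2 to compound 3. Neither has a size that can be carried over, so they predict no particular gain or loss in this assay. The expectation rests mainly on compound 3, whose > 10000 nM is a limit. No shift beyond the scatter is expected in either direction, and the estimated step is a step that the limit leaves unreadable from compound 3 to compound 4. Compound 4 will most likely report a limit again. For compound 4 the estimated value is 20000 nM, with an expected range from 6000 nM to 60000 nM.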

Compound 4, half-maximal inhibitory concentration: > 10000 nM
Compound 4: no number, only a limit (the forecaster's own chance of this, stated with the estimate: 85%); the middle value is on the limit's open side.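

No step from compound 1, compound 2 or compound 3 to compound 4 can be read in this assay, because all four results are limits and not numbers: the limit of > 10000 nM in this assay, at which 4 of the 4 values shown sit.

The compounds shown leave open whether these four differ from one another at all, and whether any change on the shared core would give a readable value.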